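Thienyl swap on a triaryl pyridine core: topoisomerase notes

The source may report more compounds than this note shows. Statements on the series, on what has been measured and on what is new or still open speak of the compounds shown alone.

Three measured members of the series share a six-membered aromatic ring with one nitrogen carrying three five-membered aromatic substituents. Compound 1 `Clc1ccc(-c2cc(-c3ccsc3)nc(-c3ccco3)c2)o1`, compound 2 `Clc1ccc(-c2cc(-c3ccco3)nc(-c3cccs3)c2)o1` and compound 3 `Clc1ccc(-c2cc(-c3ccoc3)cc(-c3cccs3)n2)cc1` were run in an assay on isolated protein for inhibition of DNA topoisomerase 1 (Homo sapiens), tested at 100 uM; on this read-out lower numbers stand for a weaker effect and higher numbers for a stronger effect at the one concentration tested. There compound 1 gives 8.2%, compound 2 gives 16% and compound 3 gives 0%.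

Compounds 2 and 1 differ in a single place, (thiophen-3-yl in place of thiophen-2-yl on an aromatic carbon), and this gives a number 7.8 percentage points lower from compound 2 to compound 1 (within the scatter). The difference between the core of compound 2 and the core of compound 3 is not broken down here. Compound 3 and compound 1 lie within the scatter of each other, while compound 2 stands above compound 3 by a margin beyond the scatter.

Compound 4 `Clc1ccc(-c2cc(-c3ccoc3)cc(-c3ccsc3)n2)cc1` is not yet measured. It differs from compound 3 by thiophen-3-yl in place of thiophen-2-yl on an aromatic carbon. This is the same kind of change as that from compound 2 to compound 1, though the surroundings differ: in compound 4 the place is meta to a 4-chlorophenyl group and meta to a furan-3-yl group, whereas in compound 1 it is meta to a 5-chlorofuran-2-yl group and meta to a furan-2-yl group. Going by the values given here, the only guide is the one measured instance, which stayed within the scatter, so the step from compound 3 to compound 4 is expected to be small, a number 4 percentage points higher from compound 3 to compound 4 (within the scatter), resting on a number 7.8 percentage points lower from compound 2 to compound 1 (within the scatter). Compound 4 is accordingly estimated at 4% in this assay, with a plausible range from 0% to 14%.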

Compound 4, a percentage reported as inhibition, at one concentration (the size of the read-out at that concentration, not a potency): 0%
Compound 4: middle estimate off by 4 percentage points, on the high side, and the stated range covers the measured number.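

In this assay the replacement of thiophen-2-yl by thiophen-3-yl gives no change at the digits printed from compound 3 to compound 4 (within the scatter), and the two cores do not part when the new step is set beside the earlier one: the same change on two cores in this assay, a number 7.8 percentage points lower (within the scatter) from compound 2 to compound 1 and no change at the digits printed (within the scatter) from compound 3 to compound 4, 7.8 percentage points apart, within the scatter of two such steps

Across these two pairs, the change carries from one core to the other as a step within the scatter, and neither pair gives a step beyond it. Going by these compounds alone, this does not show that thiophen-2-yl and thiophen-3-yl are interchangeable throughout the series: there are only two pairs, each read at one concentration, and compound 3 at 0% leaves no visible room on its core for a lower number.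

The compounds shown leave open whether the same change stays within the scatter on a core that gives a much higher number in this assay, and which of the differences between the core of compound 2 and the core of compound 3 accounts for the gap between those two compounds. They also leave open what an amine, a carboxylic acid or a longer chain would do on any of the aryl groups, since all four compounds carry only chlorine and aromatic rings on the shared core.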